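Chloro addition on a fused bicyclic core: cytotoxicity notes

This account rests on a few compounds, and the source may have more. Where it says the series, first, only, none or still open, it means among the compounds named here.

In a functional assay on K562 cells (Homo sapiens) for cytotoxicity, read by sulforhodamine B assay, with a stated time of 48 h (a lower number here means that less compound is tolerated, a higher number that more compound is tolerated), compound 1 `ClCc1ccccc1Cn1cnc2c(Cl)nc(Cl)nc21` gives 910 nM. Compound 2 `ClCc1ccccc1Cn1cnc2c(Cl)ncnc21` lacks one chlorine, the difference being (chloro in place of hydrogen on an aromatic carbon), and in this assay compound 2 reaches > 100000 nM, which is a limit of the assay rather than a number (the limit of > 100000 nM in this assay, at which 1 of the 3 values shown sits). The step of an at least 100-fold lower number from compound 2 to compound 1 (2.04 log units; beyond the scatter) is thus a large gain. Compound 3 `ClCc1ccccc1Cn1cnc2ncnc(Cl)c21` has the same atoms as compound 2 joined differently; the difference between the two cores is not broken down here. In this assay compound 3 gives 83200 nM. Compound 4 `ClCc1ccccc1Cn1cnc2nc(Cl)nc(Cl)c21` carries, relative to compound 3, the change (chloro in place of hydrogen on an aromatic carbon), at a place described in the same words as for compound 1. The step from compound 3 to compound 4 is expected to be of comparable size, a 69-fold lower number from compound 3 to compound 4 (1.84 log units; beyond the scatter), resting on an at least 100-fold lower number from compound 2 to compound 1 (2.04 log units; beyond the scatter). Compound 4 is estimated at 1200 nM, between 250 nM and 8000 nM.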

Compound 4, concentration lethal to 50% of the cells: > 100000 nM
Compound 4: no number, only a limit; the forecaster's own chance of this, stated with the estimate: 5%; middle value at least 83-fold (1.92 log units) from the limit.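

In this assay compound 4 gives > 100000 nM, a limit of the assay and not a number. The same chloro in place of hydrogen on an aromatic carbon gives an at least 1.2-fold higher number from compound 3 to compound 4 (0.07 log units; that floor lies within the scatter), so the large step seen on the core of compound 1 does not carry over to the core of compound 3: the same change on two cores in this assay, an at least 100-fold lower number (2.04 log units; beyond the scatter) from compound 2 to compound 1 and an at least 1.2-fold higher number (0.07 log units; that floor lies within the scatter) from compound 3 to compound 4, at least 130-fold (2.12 log units) apart, beyond the scatter of two such steps Not shown are the actual size of this step and whether the difference extends to any core other than these two: the limit of > 100000 nM in this assay, at which 2 of the 4 values shown sit.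

On these data alone, whether an amine or a methoxy group in place of chloro would give steps that match or differ on the two cores stays open.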